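Halogen and para substituent in the aryl urea series

This account rests on a few compounds, and the source may have more. Where it says the series, first, only, none or still open, it means among the compounds named here.

Measured so far in a functional assay (aorta) with Rattus norvegicus as the target; on this read-out higher numbers stand for an effect only at larger amounts of compound and lower numbers for an effect already at smaller amounts:
compound 1, `COc1ccc(NC(=O)NC2CC(C)(C)Oc3ccc(F)cc32)cc1`, 15500 nM
compound 2, `COc1ccc(NC(=O)NC2CC(C)(C)Oc3ccc(Cl)cc32)cc1`, > 30000 nM

Compound 1 gives a number in this assay, 15500 nM. Compound 2 returns only a limit of this assay, > 30000 nM, so no number is known for it; this is the limit of > 30000 nM in this assay, at which 1 of the 2 values shown sits. Within the data shown here, the one step between them, an at least 1.9-fold higher number from compound 1 to compound 2 (0.28 log units; that floor lies within the scatter), is a chloro in place of fluoro on an aromatic carbon and is itself bounded only by that limit.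

Compound 3, `Cc1ccc(NC(=O)NC2CC(C)(C)Oc3ccc(Cl)cc32)cc1`, is the next member. It differs from compound 2 by methyl in place of methoxy on an aromatic carbon. Among the measured compounds shown here, no measured step in this assay touches the methoxy group: the only step available, from fluoro to chloro, concerns the other ring, and compound 2 itself supplies only a limit. The expectation therefore rests on nothing more than the position of compound 2 at the limit, and the step that the limit leaves unreadable from compound 2 to compound 3 is estimated as none beyond the scatter. For compound 3 the estimate in this assay is 40000 nM, within 15000 nM to 120000 nM, with a limit again the most likely outcome.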

Compound 3, half-maximal effective concentration: > 30000 nM
Compound 3: a limit, no number; the forecaster's own chance of this, stated with the estimate: 70%; the middle value is on the limit's open side.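

No step can be read from compound 2 to compound 3, methyl in place of methoxy, as both compounds end at the same limit: the limit of > 30000 nM in this assay, at which 2 of the 3 values shown sit.

The compounds shown leave open what the change from 4-methoxyphenyl to 4-methylphenyl does to the number in this assay, and whether compound 2 and compound 3 have a number there at all.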